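The compounds below may be only part of what the source reports. "The series", "measured", "known", "first", "only" and "open" are said of these compounds alone.

Of the compounds shown here, three built on a shared core have been measured in a functional assay on HepG2 cells (Homo sapiens) for cytotoxicity, read by MTT assay, with a stated time of 24 h; on this read-out lower numbers stand for stronger inhibition and higher numbers for weaker inhibition. Compound 1 `CN1C/C(=C\c2ccc(C#N)cc2)C(=O)/C(=C/c2ccccc2F)C1` gives 590 nM, compound 2 `CN1C/C(=C\c2ccc(F)cc2)C(=O)/C(=C/c2ccc(C#N)cc2)C1` gives 6140 nM, and compound 3 `CN1C/C(=C\c2ccc(C#N)cc2)C(=O)/C(=C/c2ccc(Cl)cc2Cl)C1` gives 6250 nM. Compound 2 cannot be separated from compound 3, since a 1.0-fold higher number from compound 2 to compound 3 (0.01 log units; within the scatter) lies within the scatter. Compound 1 stands apart from both, with a 10-fold higher number from compound 1 to compound 2 (1.02 log units; beyond the scatter) and an 11-fold higher number from compound 1 to compound 3 (1.03 log units; beyond the scatter), each beyond the scatter.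

The next compound is compound 4 `CN1C/C(=C\c2ccc(C#N)cc2)C(=O)/C(=C/c2ccc(C(F)(F)F)cc2)C1`, which differs from compound 2 by trifluoromethyl in place of fluoro on an aromatic carbon, para to a large group: trifluoromethyl in place of fluoro on an aromatic carbon. Within the data shown here, no measured step makes this exchange, so the evidence is indirect. Both large steps start from compound 1, and compound 4 does not carry the group that sets compound 1 apart. Among the measured compounds shown here, the one step between two compounds lacking that group, a 1.0-fold higher number from compound 2 to compound 3 (0.01 log units; within the scatter), shows no change beyond the scatter. On that thin basis, no step beyond the scatter is expected in this assay. The expected step is a 1.1-fold lower number from compound 2 to compound 4 (0.05 log units; within the scatter). For compound 4 the estimated value is 5500 nM, with an expected range from 2000 nM to 15000 nM.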

Compound 4, half-maximal inhibitory concentration: 980 nM
For compound 4 the middle estimate is 5.6-fold (0.75 log units) above the measured one; measured number outside the range, below it.
By their numbers in this assay, from the lowest: compounds 1 and 4 (each within the scatter of the next); then compounds 2 and 3 (each within the scatter of the next).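

In this assay, the exchange of fluoro for trifluoromethyl on an aromatic carbon, para to a large group, gives a 6.3-fold lower number from compound 2 to compound 4 (0.80 log units; beyond the scatter), so a change at this position can move the number beyond the scatter, which a 1.0-fold higher number from compound 2 to compound 3 (0.01 log units; within the scatter) had not shown. A low number is also no longer confined to the compound bearing 2-fluorophenyl: compound 4, at 980 nM, has no such group and lies within the scatter of compound 1, at 590 nM. Nothing available here accounts for the step, which rests on one pair in which one heavy atom gives way to four.

The compounds shown leave open whether the trend depends on the trifluoromethyl group specifically or would extend to other groups on this carbon, such as a methyl, a methoxy, an amine or a carboxylic acid. They also leave open whether the same exchange would give a step of similar size with the nitrile-bearing arm replaced, and whether it would carry over to any read-out other than this one.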